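Carboxyethenyl in place of dibromoethenyl on the core

The source may hold more compounds than are shown below. What is called first, only, known or untested is meant among the compounds shown, and "the series" means these compounds.

Compound 3 `O=c1[nH]c(=O)n(C2C[C@@H](O)[C@@H](CO)O2)nc1C=C(Br)Br` was examined in a functional assay on Vero cells (Chlorocebus sabaeus) for cytotoxicity; on this read-out lower numbers stand for stronger inhibition and higher numbers for weaker inhibition. In this assay compound 3 reaches only a limit of the assay, > 500 ug/mL, and no number. Compound 1 `O=c1[nH]c(=O)n(C2C[C@@H](O)[C@@H](CO)O2)nc1/C=C/Br` gives 355 ug/mL in this assay. Compound 2 `O=c1[nH]c(=O)n(C2C[C@@H](O)[C@@H](CO)O2)nc1/C=C/Cl` likewise gives only a limit, > 500 ug/mL, in this assay. The step of an at least 1.4-fold higher number from compound 1 to compound 3 (0.14 log units; that floor lies within the scatter) therefore has only a floor, and the step that the two limits leave unreadable from compound 2 to compound 3 cannot be read at all, since (the limit of > 500 ug/mL in this assay, at which 2 of the 3 values shown sit). Compound 4 `O=C(O)/C=C/c1nn(C2C[C@@H](O)[C@@H](CO)O2)c(=O)[nH]c1=O` differs from compound 3 by 2-carboxyethenyl in place of 2,2-dibromoethenyl on an aromatic carbon. Within the data shown here, none of the measured steps exchanges a halogenated ethenyl for a carboxyethenyl, and both steps ending at compound 3 run into the limit, so nothing measured speaks for a movement beyond the scatter in this assay. The step that the limit leaves unreadable from compound 3 to compound 4 is expected to stay within the scatter. Compound 4 is therefore estimated at 600 ug/mL in this assay, within 300 ug/mL to 1200 ug/mL, and will most probably be reported once more only as a limit.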

Compound 4, concentration for 50% inhibition: > 500 ug/mL
Compound 4 ended at the assay's limit; the forecaster's own chance of this, stated with the estimate: 75%; the middle value is on the limit's open side.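

Among these compounds, with the 2-carboxyethenyl group, which brings a hydrogen-bond donor and a carboxy group onto the chain, the position now carries a non-halogenated ethenyl for the first time, and in this assay compound 4 still gives only a limit, not a number. Among the compounds shown here, the one step that can be read, an at least 1.4-fold higher number from compound 1 to compound 4 (0.14 log units; that floor lies within the scatter), offers only a floor and so shows no clear separation from the bromo compound. The steps from compound 2 and from compound 3 to compound 4 cannot be read, and the series now has little numerical contrast at this position: the limit of > 500 ug/mL in this assay, at which 3 of the 4 values shown sit.

As far as these compounds go, how far compound 2, compound 3 and compound 4 lie from one another therefore stays open. From the compounds shown here alone, it also stays open whether an amine, a methyl ester or a longer chain on this aromatic carbon would give a number in this assay.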